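The compounds below may be only part of what the source reports. "The series", "measured", "known", "first", "only" and "open" are said of these compounds alone.

In an ADME assay on H1-HeLa cells (Homo sapiens) for cytotoxicity, read by MTT assay, with a stated time of 3 days (a lower number here means that less compound is tolerated, a higher number that more compound is tolerated), compound 1 `CCOC(=O)c1cc2ccc(Oc3ccnc(C(=O)NC)c3)cc2s1` reads > 100000 nM, which is a limit of the assay and not a number. Among the compounds with values here, compound 2 `CNC(=O)c1cc(Oc2ccc3cc(C(=O)OC(C)C)sc3c2)ccn1` gives 45700 nM, the only true number so far. Compound 3 `CNC(=O)c1cc(Oc2ccc3c(C)c(C(=O)OC(C)C)sc3c2)ccn1` differs from compound 2 by methyl in place of hydrogen on an aromatic carbon. Within the data shown here, the one measured step, an at least 2.1-fold lower number from compound 1 to compound 2 (0.34 log units; beyond the scatter), also put methyl in place of hydrogen, though on a saturated chain carbon. As far as these compounds go, its true size stays open because of the limit of > 100000 nM in this assay, at which 1 of the 2 values shown sits. A modest step toward a lower number is therefore expected, a 1.8-fold lower number from compound 2 to compound 3 (0.26 log units; within the scatter). For compound 3 the estimated value is 25000 nM, within an expected range of 10000 nM to 60000 nM.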

Compound 3, half-maximal cytotoxic concentration: 18100 nM
For compound 3 the middle estimate is 1.4-fold (0.14 log units) above the measured one, within the range that was stated.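

In this assay, within the data shown here, methyl in place of hydrogen on an aromatic carbon of the five-membered ring with 1 sulfur gives the first step with a true number at both ends: a 2.5-fold lower number from compound 2 to compound 3 (0.40 log units; beyond the scatter). This position, two ring bonds from the ring sulfur, therefore responds to methyl alone by a measurable amount. The earlier methyl step, on the saturated chain, has no fixed size: the limit of > 100000 nM in this assay, at which 1 of the 3 values shown sits. As far as these compounds go, whether an amine or a longer chain on this aromatic carbon would shift the number further, and in which direction, stays open.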